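This account rests on a few compounds, and the source may have more. Where it says the series, first, only, none or still open, it means among the compounds named here.

Measured compounds:
compound 1, `Sc1nc(NCc2ccccc2)c2ccccc2n1`: > 100000 nM
compound 2, `COc1ccc(CNc2nc(SC)nc3ncccc23)cc1`: > 100000 nM

The read-out here is a functional assay on MCF7 cells (Homo sapiens) for cytotoxicity, read by MTT assay, with a stated time of 72 h; on this read-out lower numbers stand for higher toxicity in this test and higher numbers for lower toxicity in this test. In this assay compound 1 gives > 100000 nM, which is a limit of the assay and not a measured number. Compound 2 likewise gives > 100000 nM, again a limit rather than a number. Both values therefore sit at the limit of > 100000 nM in this assay, at which 2 of the 2 values shown sit, so compound 1 stands nowhere in particular among the numbers shown: neither compound has produced a concentration that the assay could pin down, and no step between measured compounds is available.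

Compound 3, `CSc1nc(NCc2ccccc2)c2ccccc2n1`, has not yet been measured. It differs from compound 1 by methyl in place of hydrogen on a sulfur, a methyl in place of hydrogen on a sulfur. Compound 2 carries the same methylsulfanyl group and still reached only the limit, and compound 1 did too. On this basis the step from compound 1 to compound 3 is expected to be a step that the limit leaves unreadable from compound 1 to compound 3, that is, no shift beyond the usual scatter. Compound 3 is estimated at 150000 nM, within a range from 50000 nM to 500000 nM, and most likely the assay will again report only a limit.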

Compound 3, concentration lethal to 50% of the cells: > 100000 nM
Compound 3 was reported as a limit; the forecaster's own chance of this, stated with the estimate: 85%; the middle value lies beyond the limit too.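

In this assay compound 3 gives > 100000 nM, which is a limit and not a number. Compound 1 also stands at a limit, so no step from it to compound 3 can be read: the limit of > 100000 nM in this assay, at which 3 of the 3 values shown sit.

The compounds shown leave open whether methyl in place of hydrogen on the sulfur makes any difference, and whether any of them would give a true number in this assay.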